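Swapping a methoxy for fluoro on a coumarin amide

The source may hold more compounds than are shown below. What is called first, only, known or untested is meant among the compounds shown, and "the series" means these compounds.

Measured so far:
compound 1 `COc1ccc(CNC(=O)c2cc3cc(OC)c(OCCCOc4no[n+]([O-])c4S(=O)(=O)c4ccccc4)cc3oc2=O)cc1` gives 5950 nM in an ADME assay on MCF-10A cells (Homo sapiens) for cytotoxicity, read by MTT assay, with a stated time of 48 h; a higher number here means a weaker inhibitor, a lower number a stronger inhibitor;
compound 2 `COc1cc2cc(C(=O)Nc3ccccc3)c(=O)oc2cc1OCCCOc1no[n+]([O-])c1S(=O)(=O)c1ccccc1` gives 9670 nM in this assay;
compound 3 `COc1ccc(NC(=O)c2cc3cc(OC)c(OCCCOc4no[n+]([O-])c4S(=O)(=O)c4ccccc4)cc3oc2=O)cc1` gives 5470 nM in this assay.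

Compound 3 stands close to both others: a 1.1-fold lower number from compound 1 to compound 3 (0.04 log units; within the scatter) and a 1.8-fold lower number from compound 2 to compound 3 (0.25 log units; within the scatter), so no ordering among the three is secure. Compound 4 `COc1cc2cc(C(=O)Nc3ccc(F)cc3)c(=O)oc2cc1OCCCOc1no[n+]([O-])c1S(=O)(=O)c1ccccc1` is compound 3 with one change: fluoro in place of methoxy on an aromatic carbon. Among the compounds with values here, no measured step exchanges these two groups directly. The nearest guide is the change on the same ring, a 1.8-fold lower number from compound 2 to compound 3 (0.25 log units; within the scatter), which stayed within the scatter, as did a 1.6-fold higher number from compound 1 to compound 2 (0.21 log units; within the scatter). The expectation for compound 4 is therefore a step of a 1.2-fold higher number from compound 3 to compound 4 (0.07 log units; within the scatter), not beyond the scatter. Compound 4 is estimated at 6500 nM, within 3000 nM to 14000 nM.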

Compound 4, half-maximal inhibitory concentration: 7210 nM
Compound 4: middle estimate off by 1.1-fold (0.05 log units), on the low side; low and high end bracket the measured number.
By their numbers in this assay, from the lowest: compounds 3, 1, 4 and 2 (each within the scatter of the next).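

In this assay, fluoro in place of methoxy on this aromatic carbon gives a 1.3-fold higher number from compound 3 to compound 4 (0.12 log units; within the scatter), so the exchange leaves no readable mark. Fluoro in place of hydrogen at the same carbon gives a 1.3-fold lower number from compound 2 to compound 4 (0.13 log units; within the scatter), and 4-fluorophenyl in place of 4-methoxybenzyl on the amide-type nitrogen gives a 1.2-fold higher number from compound 1 to compound 4 (0.08 log units; within the scatter), so these changes also stay within the scatter. No measurement shown explains these small steps. Still open, from the compounds shown here alone, is whether an amine or a carboxylic acid on this carbon would produce a step beyond the scatter.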